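Aryl exchange on the dicarboxylic acid core

The compounds below may be only part of what the source reports. "The series", "measured", "known", "first", "only" and "open" are said of these compounds alone.

Compounds measured in this series:
compound 1, `COn1c(-c2ccc(C)cc2)c(C=O)c2cc(C#N)c(C#N)cc21`
compound 2, `COc1ccc(-c2c(C=O)c3cc(C#N)c(C#N)cc3n2OC)cc1`
compound 3, `Cc1ccc(-c2cc3cc(C(=O)O)c(C(=O)O)cc3n2O)cc1`

In an assay on isolated protein for inhibition of Amine oxidase [flavin-containing] B (Homo sapiens), read by fluorescence and spectrophotometry, with a stated time of 20 min (a lower number here means a stronger inhibitor, a higher number a weaker inhibitor), compound 1 gives 74800 nM. For compound 2 the reported value > 100000 nM is a limit of the assay, not a number. For compound 3 the reported value > 100000 nM is likewise a limit of the assay, not a number, so compound 3 stands without a figure of its own among the values shown. the limit of > 100000 nM in this assay, at which 2 of the 3 values shown sit, covers compound 2 and compound 3 alike.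

Within the data shown here, the only measured step, an at least 1.3-fold higher number from compound 1 to compound 2 (0.12 log units; that floor lies within the scatter), lies within the scatter and concerns a different exchange on a different core. The change to compound 4 `O=C(O)c1cc2cc(-c3cccs3)n(O)c2cc1C(=O)O` is thiophen-2-yl in place of 4-methylphenyl on an aromatic carbon. Among the measured compounds shown here, no measured step touches this exchange, and none touches the core of compound 3. The expectation is therefore that compound 4 is again reported as a limit, with an expected step of a number no higher from compound 3 to compound 4 (the limit leaves the size open), none beyond the scatter. Compound 4 is estimated at 100000 nM, within a range of 30000 nM to 300000 nM.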

Compound 4, half-maximal inhibitory concentration: > 100000 nM
Compound 4 was reported as a limit (the forecaster's own chance of this, stated with the estimate: 75%); the middle value sits exactly at the limit.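

In this assay, compound 3 and compound 4 are both reported only as limits of the assay, not as numbers, so no step can be read between them: the limit of > 100000 nM in this assay, at which 3 of the 4 values shown sit.

The compounds shown leave open how thiophen-2-yl and 4-methylphenyl compare on the shared core in this assay.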